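Fluoro to cyano on the sulfonyl aryl ring of compound 3

This account rests on a few compounds, and the source may have more. Where it says the series, first, only, none or still open, it means among the compounds named here.

Of the compounds shown here, three have numbers so far in an ADME assay on L02 cells (Homo sapiens) for cytotoxicity, read by MTT assay, with a stated time of 24 h; on this read-out higher numbers stand for weaker inhibition and lower numbers for stronger inhibition. Compound 1 `N#Cc1ccc(S(=O)(=O)N2C/C(=C\c3cccnc3)C(=O)/C(=C/c3ccccc3C(F)(F)F)C2)cc1` gives 13200 nM, compound 2 `Cc1ccc(S(=O)(=O)N2C/C(=C\c3ccncc3)C(=O)/C(=C/c3ccccc3C(F)(F)F)C2)cc1` gives 12800 nM, and compound 3 `O=C1/C(=C/c2ccncc2)CN(S(=O)(=O)c2ccc(F)cc2)C/C1=C\c1ccccc1C(F)(F)F` gives 12900 nM. Compound 3 therefore stands within the scatter of both other compounds, and the three numbers show no separation.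

The next structure is compound 4 `N#Cc1ccc(S(=O)(=O)N2C/C(=C\c3ccncc3)C(=O)/C(=C/c3ccccc3C(F)(F)F)C2)cc1`, which has cyano in place of fluoro on an aromatic carbon, para to a large group: cyano in place of fluoro on an aromatic carbon. The same difference reads 4-fluorophenyl to 4-cyanophenyl.

Within the data shown here, the only measured step at this place is a 1.0-fold higher number from compound 2 to compound 3 (0.00 log units; within the scatter), with fluoro in place of methyl, and it lies within the scatter. Among the measured compounds shown here, compound 1 already carries the 4-cyanophenyl group and gives 13200 nM, although no single measured step connects it to compound 4. No direct fluoro-to-cyano comparison exists yet, so this evidence is narrow, but nothing in it points to a shift in this assay. The expected result is a 1.0-fold higher number from compound 3 to compound 4 (0.00 log units; within the scatter), which is no step beyond the scatter in either direction. Compound 4 is expected at 13000 nM, with an estimated range of 8000 nM to 21000 nM.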

Compound 4, half-maximal inhibitory concentration: 17600 nM
Compound 4: the middle estimate sits 1.4-fold (0.13 log units) below what was measured; the range from low to high includes it.
By their numbers in this assay, from the lowest: compounds 2, 3, 1 and 4 (each within the scatter of the next).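

In this assay, among these compounds, the first direct fluoro-to-cyano comparison on this aromatic carbon gives a 1.4-fold higher number from compound 3 to compound 4 (0.13 log units; within the scatter) and cyano in place of methyl at the same carbon gives a 1.4-fold higher number from compound 2 to compound 4 (0.14 log units; within the scatter) so methyl, fluoro and cyano have now all been read here without a step beyond the scatter. Among the compounds shown here, the first measured step at the pyridine group, with the 4-cyanophenyl group held constant, gives a 1.3-fold higher number from compound 1 to compound 4 (0.12 log units; within the scatter) and shows that pyridin-4-yl in place of pyridin-3-yl also stays within the scatter. Nothing available explains these small differences in the numbers.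

For the compounds shown here, all the groups read at the sulfonyl aryl position so far are small and uncharged, so it remains open whether an amine, a carboxylic acid or a longer chain on this aromatic carbon would give a step beyond the scatter. The trifluoromethyl group is common to all four compounds, so the compounds shown say nothing about what replacing it with a hydrogen, a methoxy group or a chlorine would do to the number.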